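The source may hold more compounds than are shown below. What is called first, only, known or untested is meant among the compounds shown, and "the series" means these compounds.

Measured in an ADME assay on liver for metabolic stability, with Liver microsome (Homo sapiens) as the target, read by LC-MS, using microsomes (on this read-out higher numbers stand for fast clearance and lower numbers for slow clearance), each entry being a limit of the assay and not a number:
- compound 1 `Cc1cccc([C@@H](O)C(=O)N2N=CC[C@H]2C(=O)NCc2cc(Cl)ccc2-n2cnnn2)c1`: < 12 mL.min-1.g-1
- compound 2 `CC1(C[C@@H](O)C(=O)N2N=CC[C@H]2C(=O)NCc2cc(Cl)ccc2-n2cnnn2)CC1`: < 12 mL.min-1.g-1

From the compounds shown here alone, compound 2 stands at the limit of < 12 mL.min-1.g-1 in this assay, at which 2 of the 2 values shown sit, which is a limit, so its exact value is unknown.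

Compound 3 `CC(C)(C)[C@@H](O)C(=O)N1N=CC[C@H]1C(=O)NCc1cc(Cl)ccc1-n1cnnn1` keeps the core of compound 2 and changes one group, on a saturated chain carbon bound to a carbonyl carbon and an oxygen on a saturated carbon. There it carries tert-butyl in place of (1-methylcyclopropyl)methyl (tert-butyl in place of (1-methylcyclopropyl)methyl on a saturated chain carbon bound to a carbonyl carbon and an oxygen on a saturated carbon).

For the measured compounds named here, the only measured change at this place is a step that the two limits leave unreadable from compound 1 to compound 2, so no measured step gives a size to carry over. Even so, the read-out stayed at the limit across a step that the two limits leave unreadable from compound 1 to compound 2, and on that basis no step beyond the usual scatter is expected in this assay for the new group. The expected change is a step that the limit leaves unreadable from compound 2 to compound 3, with no direction favoured by the data. Most likely the assay will again report only a limit.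

As a number, the estimate for compound 3 is 10 mL.min-1.g-1, with an expected range from 5 mL.min-1.g-1 to 20 mL.min-1.g-1.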

Compound 3, intrinsic clearance in microsomes: < 12 mL.min-1.g-1
Compound 3: only a limit was reported; the forecaster's own chance of this, stated with the estimate: 75%; the middle value lies beyond the limit too.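

In this assay compound 3 gives < 12 mL.min-1.g-1, which is a limit of the assay and not a number. The steps linking compound 1, compound 2 and compound 3 therefore cannot be read, as all sit at one limit: the limit of < 12 mL.min-1.g-1 in this assay, at which 3 of the 3 values shown sit.

The compounds shown leave open the exact clearance of each, and whether 3-methylphenyl, (1-methylcyclopropyl)methyl and tert-butyl differ at all.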